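This account rests on a few compounds, and the source may have more. Where it says the series, first, only, none or still open, it means among the compounds named here.

Measured so far:

Compound 1 `Cn1nc(-c2ccccc2)c2cc(C(=N)Nc3cccc(C(F)(F)F)c3)ncc21` gives 20900 nM in a functional assay on PC-3 cells (Homo sapiens) for cytotoxicity, read by MTT assay, with a stated time of 72 h; a lower number here means a stronger inhibitor, a higher number a weaker inhibitor.
Compound 2 `COc1ccc(Cn2nc(-c3ccccc3)c3cc(C(=N)Nc4cccc(C(F)(F)F)c4)ncc32)cc1` is reported in this assay only as a limit, not a number: > 50000 nM.
Compound 3 `CN1CCN(c2ccc(NC(=N)c3cc4c(-c5ccccc5)nn(C)c4cn3)cc2)CC1` gives 5900 nM in this assay.

Among the measured compounds shown here, the one change that is measured here is 4-methoxyphenyl in place of hydrogen on a saturated chain carbon bound to an aromatic nitrogen. It brought an at least 2.3-fold higher number from compound 1 to compound 2 (0.37 log units; beyond the scatter). That this step is known only as a lower bound follows because of the limit of > 50000 nM in this assay, at which 1 of the 3 values shown sits, so the true weakening may be larger than stated.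

Compound 3 shares the change-bearing part of the molecule with compound 1, but the two cores differ in more than one place, and the difference between the two cores is not broken down here. Among the two measured numbers, compound 3 gives the lower one, and its step from compound 1 is beyond the scatter.

Compound 4 `COc1ccc(Cn2nc(-c3ccccc3)c3cc(C(=N)Nc4ccc(N5CCN(C)CC5)cc4)ncc32)cc1` has not yet been measured. Relative to compound 3 it carries 4-methoxyphenyl in place of hydrogen on a saturated chain carbon bound to an aromatic nitrogen, the same change, in the same place, as the one from compound 1 to compound 2. On that basis compound 4 is expected to be a weaker inhibitor than compound 3, with an estimated 3.4-fold higher number from compound 3 to compound 4 (0.53 log units; beyond the scatter), resting on the measured at least 2.3-fold higher number from compound 1 to compound 2 (0.37 log units; beyond the scatter) applied to the value of compound 3, 5900 nM. The estimate for compound 4 in this assay is therefore 20000 nM, expected to lie between 8000 nM and 50000 nM, with a real chance that only a limit is reported.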

Compound 4, half-maximal inhibitory concentration: 3990 nM
Estimate against measurement, compound 4: 5.0-fold (0.70 log units) above; measured number outside the range, below it.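

In this assay, the same swap of methyl to 4-methoxybenzyl on the core of compound 3 gives a 1.5-fold lower number from compound 3 to compound 4 (0.17 log units; within the scatter), a step that stays within the usual scatter of repeated measurements. Set beside the earlier step, this shows that the change does not carry over unchanged from one core to the other, since it clearly weakens the result on one core but not on the other: the same change on two cores in this assay, an at least 2.3-fold higher number (0.37 log units; beyond the scatter) from compound 1 to compound 2 and a 1.5-fold lower number (0.17 log units; within the scatter) from compound 3 to compound 4, at least 3.5-fold (0.54 log units) apart, beyond the scatter of two such steps. It does not show which difference between the two cores is responsible, and two pairs give no rule for any further core, while the earlier step has no known upper end, as compound 2 is reported only as a limit: the limit of > 50000 nM in this assay, at which 1 of the 4 values shown sits.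

From the compounds shown here alone, what a plain benzyl without the methoxy, or a longer chain ending in an amine or a carboxylic acid, would do at this place on either core remains open. Also open, going by these compounds, is whether a third core would follow compound 1 and compound 2, follow compound 3 and compound 4, or behave like neither pair.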